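The source may hold more compounds than are shown below. What is called first, only, known or untested is meant among the compounds shown, and "the series" means these compounds.

Measured in an ADME assay on L132 cells (Homo sapiens) for cytotoxicity, read by MTT assay, with a stated time of 72 h; a lower number here means a stronger inhibitor, a higher number a weaker inhibitor:
Compound 1 `COc1ccc(C2=C(c3cc(OC)c(OC)c(OC)c3)C(=O)C(O)C2)cc1F`: < 1 ug/mL
Compound 2 `CC(=O)OC1C/C(=N/O)C(c2ccccc2)=C1c1ccccc1`: > 100 ug/mL

Both entries are limits of the assay, not numbers. Compound 2 stands at its limit of > 100 ug/mL, as the limit of > 100 ug/mL in this assay, at which 1 of the 2 values shown sits, records. Compound 3 `O/N=C1/CC(O)C(c2ccccc2)=C1c1ccccc1` carries hydrogen in place of acetyl on an oxygen on a saturated carbon, acetoxy to hydroxy: hydrogen in place of acetyl on an oxygen on a saturated carbon. Among the compounds with values here, no measured pair shows this change. In this assay, no step beyond the scatter and no clear direction is expected: a number no higher from compound 2 to compound 3 (the limit leaves the size open). For compound 3 the estimate is 100 ug/mL, with an expected range of 35 ug/mL to 300 ug/mL.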

Compound 3, half-maximal inhibitory concentration: > 100 ug/mL
Compound 3 was reported as a limit; the forecaster's own chance of this, stated with the estimate: 65%; the middle value sits exactly at the limit.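

In this assay, compound 2 and compound 3 are both recorded only as limits of the assay, and no step can be read between them. The compounds shown leave open how far acetoxy to hydroxy moves the read-out.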